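This account rests on a few compounds, and the source may have more. Where it says the series, first, only, none or still open, it means among the compounds named here.

Compounds measured so far:
compound 1 `CCCN(Cc1ccccc1)c1nc(C)nc(Nc2c(C)cc(C)cc2C)n1` — 490 nM
compound 2 `CCN(Cc1ccccc1)c1nc(C)nc(Nc2ccc(C)cc2)n1` — > 10000 nM
compound 3 `CCN(Cc1ccccc1)c1nc(C)nc(Nc2c(C)cccc2C)n1` — > 10000 nM

Compound 1 `CCCN(Cc1ccccc1)c1nc(C)nc(Nc2c(C)cc(C)cc2C)n1` is the only one of the three that gives a number in an assay on isolated protein for binding affinity to corticotropin-releasing factor receptor 1 (Homo sapiens) (on this read-out lower numbers stand for stronger inhibition and higher numbers for weaker inhibition), where compound 1 reaches 490 nM. For compound 2 `CCN(Cc1ccccc1)c1nc(C)nc(Nc2ccc(C)cc2)n1` this assay reports only a limit, > 10000 nM. For compound 3 `CCN(Cc1ccccc1)c1nc(C)nc(Nc2c(C)cccc2C)n1` this assay likewise reports only a limit, > 10000 nM. For the measured compounds named here, the single step that joins two measured compounds in one place, a step that the two limits leave unreadable from compound 2 to compound 3, therefore cannot be sized, since both of its ends sit at the limit (the limit of > 10000 nM in this assay, at which 2 of the 3 values shown sit).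

Compound 4 `CCN(Cc1ccccc1)c1nc(C)nc(Nc2c(C)cc(C)cc2C)n1` differs from compound 3 by methyl in place of hydrogen on an aromatic carbon. Going by the values given here, no measured step bears directly on this change. What can be said is that compound 1 carries the same 2,4,6-trimethylphenyl group as compound 4 and gives a number, while compound 3 with 2,6-dimethylphenyl stays at the limit. On that basis the step of an at least 6.6-fold lower number from compound 3 to compound 4 (0.82 log units; beyond the scatter) is expected to move toward stronger binding, although its size cannot be read from the limit of compound 3. Compound 4 is estimated at 1500 nM, within 400 nM to 8000 nM.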

Compound 4, inhibition constant: 1470 nM
Beside the measured number, compound 4's estimate is 1.0-fold (0.01 log units) above it; the range from low to high includes it.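

In this assay, methyl in place of hydrogen on this aromatic carbon, para to a large group, gives an at least 6.8-fold lower number from compound 3 to compound 4 (0.83 log units; beyond the scatter), so the 2,4,6-trimethylphenyl group yields a number where the 2,6-dimethylphenyl group stays at a limit. The same group gives an at least 6.8-fold lower number from compound 2 to compound 4 (0.83 log units; beyond the scatter), and both steps are minimum sizes, as each starts from a limit and not from a number. With the 2,4,6-trimethylphenyl group held fixed, the saturated chain on the nitrogen can now be read, and hydrogen in place of methyl on that chain gives a 3.0-fold higher number from compound 1 to compound 4 (0.48 log units; beyond the scatter).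

On these data alone, whether methoxy or chlorine on this aromatic carbon would match methyl stays open, as does the effect of a butyl chain on the nitrogen. The true size of the methyl step also stays open: the limit of > 10000 nM in this assay, at which 2 of the 4 values shown sit.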